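A few compounds are considered here, and "the series" means these few. Any claim that something is new, unique, unknown or untested is made for them only; others in the source may bear on it.

In a functional assay on MCF7 cells (Homo sapiens) for antiproliferative activity, read by MTT assay, with a stated time of 72 h (on this read-out higher numbers stand for weaker inhibition and lower numbers for stronger inhibition), compound 1 (`C=CC/N=C1\S/C(=C\c2ccc(OC)cc2)C(=O)N1C`) gives > 100000 nM, which is a limit of the assay and not a number. Compound 1 therefore stands at the limit of > 100000 nM in this assay, at which 1 of the 2 values shown sits. Going by the values given here, the only actual number comes from compound 2 (`COc1ccc(/C=C2/CN(C)/C(=N/c3ccc(C(C)(C)C)cc3)S2)cc1`), which gives 28700 nM in this assay. Compound 3 (`COc1ccc(/C=C2\S/C(=N\c3ccc(Cl)cc3)N(C)C2=O)cc1`) is still to be measured. It carries 4-chlorophenyl in place of allyl on a double-bonded nitrogen. Among the compounds with values here, no measured step shows what such a change does, so only a modest move towards stronger inhibition is expected in this assay, and the assay may again report only a limit. The expected change is an at least 2.8-fold lower number from compound 1 to compound 3 (0.45 log units; beyond the scatter). This expectation is anchored on compound 2 at 28700 nM, and nothing shown supports a much stronger result. Compound 3 is estimated at 35000 nM, with an expected range from 9000 nM to 100000 nM.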

Compound 3, half-maximal inhibitory concentration: 39300 nM
Compound 3: middle estimate off by 1.1-fold (0.05 log units), on the low side; the range from low to high includes it.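

At this position, the double-bonded nitrogen, 4-chlorophenyl in place of allyl now has a measured effect in this assay: an at least 2.5-fold lower number from compound 1 to compound 3 (0.40 log units; beyond the scatter). Going by these compounds alone, an aromatic ring on this nitrogen therefore brings the shared core within the range that this assay can put a number on, which the earlier compounds did not show for this change. The step gives a bound and not a size, because the value of compound 1 is a limit: the limit of > 100000 nM in this assay, at which 1 of the 3 values shown sits.

The compounds shown leave open whether the shift belongs to the aromatic ring itself or to its chlorine, which a plain phenyl at the same nitrogen would separate. They also leave open how a 4-methoxyphenyl, a 4-aminophenyl or a longer chain would read there.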